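The source may report more compounds than this note shows. Statements on the series, on what has been measured and on what is new or still open speak of the compounds shown alone.

Measured in a functional assay on MCF7 cells (Homo sapiens) for inhibition, read by MTT assay, with a stated time of 72 h; on this read-out higher numbers stand for weaker inhibition and lower numbers for stronger inhibition:
Compound 1 `O=C(Nc1ccccc1)C1CCN(C/C=C/c2ccccc2)CC1`: 60200 nM
Compound 2 `O=C(Nc1ccc(F)c(Br)c1)C1CCN(C/C=C/c2ccccc2)CC1`: 13500 nM

Compound 2 holds the lower of the two numbers in this assay. Compound 3 `N#Cc1ccc(NC(=O)C2CCN(C/C=C/c3ccccc3)CC2)cc1` alters the same group on the amide-type nitrogen: 4-cyanophenyl in place of 3-bromo-4-fluorophenyl on an amide-type nitrogen. Within the data shown here, only one measured step bears on this place, a 4.5-fold lower number from compound 1 to compound 2 (0.65 log units; beyond the scatter), which is modest and beyond the scatter. Among the measured compounds shown here, no measured compound carries 4-cyanophenyl, so that step serves only as a guide to size. A modest move back towards a higher number is expected, and the estimated change is a 2.2-fold higher number from compound 2 to compound 3 (0.35 log units; beyond the scatter). For compound 3 the expected value is 30000 nM, with an estimated range of 11000 nM to 70000 nM.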

Compound 3, half-maximal inhibitory concentration: 44500 nM
Compound 3: middle estimate off by 1.5-fold (0.17 log units), on the low side, within the range that was stated.
By their numbers in this assay, from the lowest: compound 2; then compounds 3 and 1 (each within the scatter of the next).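

In this assay, 4-cyanophenyl does not keep the gain seen with 3-bromo-4-fluorophenyl on the amide-type nitrogen: the step is a 3.3-fold higher number from compound 2 to compound 3 (0.52 log units; beyond the scatter), while cyano in place of hydrogen gives a 1.4-fold lower number from compound 1 to compound 3 (0.13 log units; within the scatter), leaving compound 3 not separated from compound 1. Substitution on this ring therefore does not by itself lower the number; the result depends on which substituent is present. No available evidence accounts for this difference.

As far as these compounds go, it remains open whether bromine or fluorine alone would account for the step seen with compound 2, and how an amine or a carboxylic acid on this ring would compare.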